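This account rests on a few compounds, and the source may have more. Where it says the series, first, only, none or still open, it means among the compounds named here.

Compound 1, `Fc1ccc(-c2csc(N/N=C/c3ccc(Cl)cc3Cl)n2)cc1`, gives 95.5% in a functional assay, read by spectrophotometry, with a stated time of 15 min, tested at 80 ug/mL; a lower number here means a weaker effect, a higher number a stronger effect of the compound at the concentration tested.
Compound 2, `Cc1ccc(-c2csc(N/N=C/c3ccc(Cl)cc3Cl)n2)cc1`, gives 90.7% in this assay.
Compound 3, `COc1ccc(-c2csc(N/N=C/c3ccc(Cl)cc3Cl)n2)cc1`, gives 90.6% in this assay.

Compound 3 has the lowest of the three numbers, but none of the gaps is beyond the scatter: its nearest neighbour is compound 2, a number 0.1 percentage points lower from compound 2 to compound 3 (within the scatter), and its furthest is compound 1, a number 4.9 percentage points lower from compound 1 to compound 3 (within the scatter). The three measured compounds thus behave alike in this assay.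

Compound 4, `Clc1ccc(-c2csc(N/N=C/c3ccc(Cl)cc3Cl)n2)cc1`, has not yet been measured. It differs from compound 3 in one place: chloro in place of methoxy on an aromatic carbon. Among the measured compounds shown here, the steps that bear on this change are the ones at the same aromatic carbon, a number 4.8 percentage points lower from compound 1 to compound 2 (within the scatter), a number 4.9 percentage points lower from compound 1 to compound 3 (within the scatter) and a number 0.1 percentage points lower from compound 2 to compound 3 (within the scatter), all within the scatter. Three different groups at this carbon have left the readout where it stands, so no step beyond the scatter is expected for the move to chloro; the expected step is a number 0.4 percentage points higher from compound 3 to compound 4 (within the scatter). For compound 4 the estimate in this assay is 91%, with a range from 83% to 97%.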

Compound 4, a percentage reported as inhibition, at one concentration (the size of the read-out at that concentration, not a potency): 92.3%
Compound 4: middle estimate off by 1.3 percentage points, on the low side, and the stated range covers the measured number.
By their numbers in this assay, from the lowest: compounds 3, 2, 4 and 1 (each within the scatter of the next).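

With chloro, a fourth group at this aromatic carbon, para to a large group, leaves the read-out in this assay where it stood: the move from methoxy gives (a number 1.7 percentage points higher from compound 3 to compound 4 (within the scatter)), the move from methyl gives (a number 1.6 percentage points higher from compound 2 to compound 4 (within the scatter)) and the move from fluoro gives (a number 3.2 percentage points lower from compound 1 to compound 4 (within the scatter)). Chloro thus adds a second halogen to the series, and the 4-methoxyphenyl to 4-chlorophenyl change shows that losing the methoxy oxygen, with its hydrogen-bond acceptor, produces no step beyond the scatter. No independent data here explain this flat behaviour.

The compounds shown leave open whether a group of another kind at this carbon, such as an amine, a carboxylic acid or a longer alkyl chain, would also leave the read-out in place. They also leave open whether this holds once another part of the shared core is changed.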